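The compounds below may be only part of what the source reports. "The series", "measured", "known", "first", "only" and "open" are said of these compounds alone.

Measured in a functional assay on CHO cells with adenosine receptor A1 (Homo sapiens) as the target, read by cAMP accumulation and immunoassay, with a stated time of 6 min, tested at 0.1 uM; a lower number here means a stronger effect, a higher number a weaker effect of the compound at the concentration tested:

compound 1 `Nc1scc(CN2CCN(c3ccc(Cl)cc3Cl)CC2)c1C(=O)c1ccc(Cl)cc1` gives -11%;
compound 2 `Nc1scc(CN2CCN(c3cc(Cl)cc(Cl)c3)CC2)c1C(=O)c1ccc(Cl)cc1` gives -22%;
compound 3 `Nc1scc(CN2CCN(c3cccc(F)c3F)CC2)c1C(=O)c1ccc(Cl)cc1` gives -5.2%.

Among these three numbers compound 1 stands second highest. Its nearest neighbour is compound 3, a step within the scatter: a number 5.8 percentage points higher from compound 1 to compound 3 (within the scatter). Its furthest neighbour is compound 2, a modest step beyond the scatter: a number 11 percentage points lower from compound 1 to compound 2 (beyond the scatter). Between the other two, a number 16.8 percentage points higher from compound 2 to compound 3 (beyond the scatter) is likewise modest.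

Compound 4 `Nc1scc(CN2CCN(c3cc(F)ccc3F)CC2)c1C(=O)c1ccc(Cl)cc1` has not been measured in this assay. It differs from compound 1 in one place: 2,5-difluorophenyl in place of 2,4-dichlorophenyl on an amine nitrogen in a ring

Among the compounds with values here, the step that bears on this change most closely is the one from compound 1 to compound 3, where a difluorophenyl also replaced the 2,4-dichlorophenyl on the amine nitrogen in the ring and the number moved only within the scatter. Within the data shown here, the steps to and from compound 2 show that a rearranged dichlorophenyl can move the number modestly, but no step from a 2,5-difluorophenyl is available. The expectation for this assay is therefore a small step, if any, not beyond the scatter, and with a slight lean upward like that seen for compound 3. Compound 4 is estimated at -7%, with a range from -24% to 10%. The expected step is a number 4 percentage points higher from compound 1 to compound 4 (within the scatter).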

Compound 4, a percentage reported as activity, at one concentration (the size of the read-out at that concentration, not a potency): -13%
Compound 4: middle estimate off by 6 percentage points, on the high side, and the stated range covers the measured number.
By their numbers in this assay, from the lowest: compounds 2, 4, 1 and 3 (each within the scatter of the next, the first and the last beyond it).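

In this assay, the change to the 2,5-difluorophenyl group gave a number 2 percentage points lower from compound 1 to compound 4 (within the scatter), so a second difluorophenyl pattern on the amine nitrogen in the ring joined the 2,3-difluorophenyl group in not separating from the 2,4-dichlorophenyl group. Moving one fluorine gave a number 7.8 percentage points lower from compound 3 to compound 4 (within the scatter), and the comparison with the 3,5-dichlorophenyl group gave a number 9 percentage points higher from compound 2 to compound 4 (within the scatter), so compound 4 lies within the scatter of all three earlier compounds, while a number 16.8 percentage points higher from compound 2 to compound 3 (beyond the scatter) remains the only step among the four compounds that is beyond it. Nothing at hand gives a reason for any of these steps.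

All four compounds carry two halogens on this phenyl ring, so the compounds shown leave open what an unsubstituted phenyl, a single chlorine, or a methoxy or trifluoromethyl group would do at this position. They also leave open whether these small steps would hold at other concentrations, since each compound is read at a single concentration and the rest of the core stays the same throughout.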